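Losing one methoxy group: what growth inhibition may follow

The compounds below may be only part of what the source reports. "The series", "measured", "known", "first", "only" and "open" are said of these compounds alone.

In a functional assay on A549 cells (Homo sapiens) for cytotoxicity, read by sulforhodamine B assay, with a stated time of 48 h (on this read-out higher numbers stand for weaker inhibition of growth and lower numbers for stronger inhibition of growth), compound 1 (`COc1ccc(C(=O)c2cc(OC)c(OC)c(OC)c2)c(OC)c1O`) gives 41.3 nM and compound 2 (`COc1ccc(C(=O)c2cc(OC)c(OC)c(OC)c2)c(OC)c1N`) gives 39 nM. The step between them is a 1.1-fold lower number from compound 1 to compound 2 (0.02 log units; within the scatter), so compound 2 shares the low end of the three numbers with compound 1. Compound 3 (`COc1ccc(C(=O)c2cc(OC)c(OC)c(OC)c2)c(OC)c1NC(C)=O`) stands apart at 4620 nM, and a 110-fold higher number from compound 1 to compound 3 (2.05 log units; beyond the scatter) is a large step.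

Compound 4 (`COc1ccc(C(=O)c2cc(OC)c(OC)c(OC)c2)cc1N`) departs from compound 2 by one change, hydrogen in place of methoxy on an aromatic carbon. For the measured compounds named here, no measured step touches this methoxy group, so the data offer no direct guide to its removal. Compound 4 does keep the amino group of compound 2, whereas the large step of a 120-fold higher number from compound 2 to compound 3 (2.07 log units; beyond the scatter) came with acetyl in place of hydrogen on that nitrogen. A step of that size is therefore not expected, and no firm direction can be given. The expected step is a 1.3-fold lower number from compound 2 to compound 4 (0.11 log units; within the scatter), and the range is kept wide. For compound 4 the estimated value is 30 nM, with an expected range of 6 nM to 200 nM.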

Compound 4, concentration for 50% growth inhibition: 57 nM
Compound 4: middle estimate off by 1.9-fold (0.28 log units), on the low side, within the range that was stated.
By their numbers in this assay, from the lowest: compounds 2, 1 and 4 (each within the scatter of the next); then compound 3.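

In this assay, for the compounds shown here, the step of a 1.5-fold higher number from compound 2 to compound 4 (0.16 log units; within the scatter) is the first reading at this position, and it shows that the methoxy group ortho to a large group and ortho to an amino group can give way to hydrogen without a step beyond the scatter. Among the steps shown, the large ones remain those that came with the acetamido group of compound 3, and the loss of this methoxy group does not add another. No evidence in hand says why this change leaves the number within the scatter.

On these data alone, whether a larger group at this position, such as ethoxy or a longer alkoxy chain, would keep the number in this range stays open. As far as these compounds go, it is also open whether hydrogen would serve equally well with the hydroxy group of compound 1 in place of the amino group.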